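The compounds below may be only part of what the source reports. "The series", "measured", "known", "first", "only" and "open" are said of these compounds alone.

Compound 1 `CCc1ccc(SCc2ccc(/C=C/C(=O)Nc3ccccc3N)cc2)cc1`: 60.7%
Compound 2 `COc1ccc(SCc2ccc(C(=O)Nc3ccccc3N)cc2)cc1`: 45.7%

The read-out here is a functional assay on A549 cells (Homo sapiens) for inhibition, read by CCK-8 assay, with a stated time of 72 h, tested at 2 uM; on this read-out higher numbers stand for more inhibition of growth at the one concentration tested and lower numbers for less inhibition of growth. Going by the values given here, on this measure compound 2 gives 45.7%, the lower of the two numbers so far. Compound 1 stands at 60.7%, higher by more than the usual scatter of repeated measurements. These two compounds differ in more than one place, so their gap cannot be tied to any single group.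

The next compound, compound 3 `Nc1ccccc1NC(=O)c1ccc(CSc2cccc(F)c2)cc1`, differs from compound 2 in one place: 3-fluorophenyl in place of 4-methoxyphenyl on a sulfur. Put simply, 3-fluorophenyl stands in place of 4-methoxyphenyl on a sulfur, and the rest of the structure stays the same. Among the compounds with values here, no measured pair shows what a swap of this kind does on its own, so neither its size nor its direction has direct support. The nearest guide is compound 2 at 45.7%, and no change beyond the scatter is expected in this assay. The expected step is a number 0.7 percentage points lower from compound 2 to compound 3 (within the scatter). The estimate for compound 3 is 45%, with an expected range of 28% to 62%.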

Compound 3, percent growth inhibition at one concentration: 46.9%
Compound 3: the middle estimate sits 1.9 percentage points below what was measured; measured number inside the range.
By their numbers in this assay, from the lowest: compounds 2 and 3 (each within the scatter of the next); then compound 1.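

In this assay, going by these compounds alone, putting 3-fluorophenyl in place of 4-methoxyphenyl on a sulfur gives a number 1.2 percentage points higher from compound 2 to compound 3 (within the scatter) and this is the first pair in which a change at this position can be read on its own. The aromatic ring on the sulfur can therefore carry a different group at a different ring position, with one fewer heavy atom and one fewer hydrogen-bond acceptor, and the two numbers still cannot be told apart at the single concentration tested. Nothing measured here explains why these two groups read alike.

As far as these compounds go, it remains open whether this position would accept something quite different, such as an amine or a carboxylic acid on the phenyl ring, or a longer chain in place of the ring altogether. Compound 2 and compound 3 each still differ in more than one place from compound 1, so the higher number of compound 1 at 60.7% cannot yet be tied to any single group.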